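Methoxyphenyl isomers on the shared core

The compounds below may be only part of what the source reports. "The series", "measured", "known", "first", "only" and "open" are said of these compounds alone.

Compound 1 `COc1cccc(-c2ccc3ncn(-c4cc(OC)c(OC)c(OC)c4)c3c2)c1`: 3310 nM
Compound 2 `COc1ccc(-c2ccc3ncn(-c4cc(OC)c(OC)c(OC)c4)c3c2)cc1`: 82 nM
Compound 3 `COc1ccccc1-c1ccc2ncn(-c3cc(OC)c(OC)c(OC)c3)c2c1`: not yet measured

Two compounds have numbers in a functional assay on SGC-7901 cells (Homo sapiens) for antiproliferative activity, read by MTT assay, with a stated time of 72 h; on this read-out higher numbers stand for weaker inhibition and lower numbers for stronger inhibition. Compound 2 stands lowest of the two; its nearest neighbour is compound 1, and the step of a 40-fold lower number from compound 1 to compound 2 (1.61 log units; beyond the scatter) is large and well beyond the scatter. Nothing else has been measured, so the whole picture of this series rests on that single pair.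

Compound 3 differs from compound 2 only in the change (2-methoxyphenyl in place of 4-methoxyphenyl on an aromatic carbon). Among the compounds with values here, the one measured step that bears on it is the move of the methoxy group from the 3-methoxyphenyl to the 4-methoxyphenyl, which cut the number sharply. Within the data shown here, the move to 2-methoxyphenyl is a further relocation of the same group away from the arrangement of compound 2, and on the single comparison available the expectation is that the number rises again, by a step of roughly the size seen between compound 1 and compound 2, though with wide uncertainty because only one step is known. The estimated step is an 18-fold higher number from compound 2 to compound 3 (1.26 log units; beyond the scatter). For compound 3 the expected value in this assay is 1500 nM, with a range from 250 nM to 9000 nM.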

Compound 3, half-maximal inhibitory concentration: 5050 nM
Estimate against measurement, compound 3: 3.4-fold (0.53 log units) below; the range from low to high includes it.
By their numbers in this assay, from the lowest: compound 2; then compounds 1 and 3 (each within the scatter of the next).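

With the methoxy group now read at all three places on this phenyl ring in this assay, the 4-methoxyphenyl of compound 2 stands alone, and replacing it with 2-methoxyphenyl gives a 62-fold higher number from compound 2 to compound 3 (1.79 log units; beyond the scatter). The 2-methoxyphenyl and 3-methoxyphenyl isomers cannot be told apart, with a 1.5-fold higher number from compound 1 to compound 3 (0.18 log units; within the scatter), so among these compounds the low number belongs to the 4-methoxyphenyl arrangement only, and the two other placements on this shared core give values within the usual scatter of each other. Nothing available explains why the 4-methoxyphenyl isomer differs so sharply from the other two.

The compounds shown leave open whether the low number of compound 2 needs the methoxy group itself, since a 4-ethoxyphenyl, 4-hydroxyphenyl, 4-fluorophenyl or 4-dimethylaminophenyl group, or a plain phenyl, on the same aromatic carbon would test that. Also open, from the compounds shown here alone, is whether the same sharp dependence on the methoxy placement would hold in other cell lines or with a different group on the ring nitrogen of the shared core.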